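Compound 2 to compound 3: chloro replaced by methoxy

This account rests on a few compounds, and the source may have more. Where it says the series, first, only, none or still open, it means among the compounds named here.

Two members of the series have numbers in a functional assay on PC-3 cells (Homo sapiens) for antiproliferative activity, read by MTT assay, with a stated time of 48 h; on this read-out higher numbers stand for weaker inhibition and lower numbers for stronger inhibition. Compound 1 `Cc1ccc(S(=O)(=O)NC(=O)[C@H](CC(C)C)NC2=NC(=O)/C(=C/c3cccc(Cl)c3)S2)cc1` gives 16.8 ug/mL in this assay, and compound 2 `Cc1ccc(S(=O)(=O)NC(=O)[C@@H](NC2=NC(=O)/C(=C/c3ccccc3Cl)S2)C(C)C)cc1` gives 11.9 ug/mL. Among the measured compounds shown here, the two values sit within the usual scatter of one another, so the numbers so far do not separate compound 2 from compound 1; compound 2 simply serves as the starting point for the next step.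

Compound 3 `COc1ccccc1/C=C1\SC(N[C@H](C(=O)NS(=O)(=O)c2ccc(C)cc2)C(C)C)=NC1=O` has not yet been measured. It differs from compound 2 in a single place: methoxy in place of chloro on an aromatic carbon. Cut one bond further out, the same difference reads 2-chlorophenyl to 2-methoxyphenyl.

For the measured compounds named here, no step between measured compounds covers this change, and the two values known are within the scatter of each other, so nothing points the step in either direction. The step is therefore expected to be small, a 1.2-fold higher number from compound 2 to compound 3 (0.07 log units; within the scatter), not beyond the scatter. Compound 3 is estimated at 14 ug/mL in this assay, with a range from 7 ug/mL to 28 ug/mL.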

Compound 3, half-maximal inhibitory concentration: 15 ug/mL
Compound 3: the middle estimate sits 1.1-fold (0.03 log units) below what was measured, and the stated range covers the measured number.
By their numbers in this assay, from the lowest: compounds 2, 3 and 1 (each within the scatter of the next).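

In this assay, the series now has its first step between compounds that differ in one place: methoxy in place of chloro, on an aromatic carbon ortho to a large group, gives a 1.3-fold higher number from compound 2 to compound 3 (0.10 log units; within the scatter). At this position, the exchange of 2-chlorophenyl for 2-methoxyphenyl brings one more heavy atom and one hydrogen-bond acceptor, yet the read-out does not separate the two compounds. No measurement on hand bears on why the two groups read alike.

This single step leaves open whether a group of another kind at the same position, such as an amine, a carboxylic acid or a longer alkoxy chain, would give a step beyond the scatter. Compound 1 differs from compound 2 and from compound 3 in more than one place, so the separate contributions of the side chain and of the place of the chloro group on the aromatic ring also remain unresolved.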